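The compounds below may be only part of what the source reports. "The series", "measured", "known", "first", "only" and "open" are said of these compounds alone.

Compound 1 `CCCCCCCCCCn1cc(/C=C/C(=O)c2ccc(NC(=O)CBr)cc2)nn1`: 9740 nM in a functional assay on A549 cells (Homo sapiens) for inhibition, read by MTT assay; on this read-out lower numbers stand for stronger inhibition and higher numbers for weaker inhibition
Compound 2 `CCCCCCCCn1cc(/C=C/C(=O)c2ccc(NC(=O)CBr)cc2)nn1`: 11600 nM in this assay

Compound 2 gives the highest of the two numbers in this assay, yet the step of a 1.2-fold higher number from compound 1 to compound 2 (0.08 log units; within the scatter) is within the scatter, so the two cannot be ordered. Compound 3 `O=C(CBr)Nc1ccc(C(=O)/C=C/c2cn(Cc3ccc(Br)cc3)nn2)cc1` carries 4-bromophenyl in place of heptyl on a saturated chain carbon bound to an aromatic nitrogen. Within the data shown here, the only measured step, a 1.2-fold higher number from compound 1 to compound 2 (0.08 log units; within the scatter), shortens the chain and bears on this change only in part; no measured step exchanges a chain for an aromatic ring. No step beyond the scatter is therefore expected in this assay, with a wide range. Compound 3 is estimated at 11000 nM, between 3500 nM and 35000 nM, a step of a 1.1-fold lower number from compound 2 to compound 3 (0.02 log units; within the scatter) expected.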

Compound 3, half-maximal inhibitory concentration: 8670 nM
For compound 3 the middle estimate is 1.3-fold (0.10 log units) above the measured one; measured number inside the range.
By their numbers in this assay, from the lowest: compounds 3, 1 and 2 (each within the scatter of the next).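

In this assay the saturated chain carbon bound to an aromatic nitrogen carries 4-bromophenyl in place of heptyl (a 1.3-fold lower number from compound 2 to compound 3 (0.13 log units; within the scatter)) and in place of nonyl (a 1.1-fold lower number from compound 1 to compound 3 (0.05 log units; within the scatter)). An aromatic ring therefore replaces a plain chain at this place with no step beyond the scatter, which the two chain compounds alone could not show. No independent measurement bears on this result.

Still open, as far as these compounds go, is whether an amine or a carboxylic acid at this place would give a step beyond the scatter.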